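The source may report more compounds than this note shows. Statements on the series, on what has been measured and on what is new or still open speak of the compounds shown alone.

Measured so far in a functional assay on PC-3 cells (Homo sapiens) for antiproliferative activity, read by MTT assay, tested at 5 uM; a higher number here means a stronger effect of the compound at the concentration tested, a lower number a weaker effect:
- compound 1, `COc1cc(C(=O)N/N=C/c2ccccc2C(F)(F)F)cc(OC)c1OC`, gives 52.9%
- compound 2, `COc1cc(C2=NN(C(C)=O)C(c3ccc(F)cc3)O2)cc(OC)c1OC`, gives 0.1%
- compound 3, `COc1cc(C(=O)N/N=C/c2cccc(C(F)(F)F)c2)cc(OC)c1OC`, gives 79.8%

Compound 2 stands lowest of the three numbers in this assay. Its nearest neighbour is compound 1, whose number lies higher by a gap beyond the usual scatter; compound 3 lies further still above it, also beyond the scatter. For the measured compounds named here, compounds 1 and 3 share one core, compound 2 another; no pair of measured compounds differs in a single place, so no measured step exists within either core.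

The next compound, compound 4, is `COc1ccc(OC)c(C2OC(c3cc(OC)c(OC)c(OC)c3)=NN2C(C)=O)c1`. Against compound 2 the change is 2,5-dimethoxyphenyl in place of 4-fluorophenyl on a saturated ring carbon. Nothing measured here speaks to what this exchange does on the core of compound 2, since both comparisons to compound 2 involve a different core as well as a different substituent. The step from compound 2 to compound 4 in this assay is therefore expected to be small, most likely none beyond the scatter, with a slight upward lean only because compound 2 sits at 0.1% and cannot go lower by much; the expected step is a number 7.9 percentage points higher from compound 2 to compound 4 (within the scatter). For compound 4 in this assay the estimate is 8%, with a range from 0% to 30%.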

Compound 4, a percentage reported as inhibition, at one concentration (the size of the read-out at that concentration, not a potency): 43.2%
For compound 4 the middle estimate is 35.2 percentage points below the measured one; the measured number lies above the stated range.
By their numbers in this assay, from the lowest: compound 2; then compounds 4 and 1 (each within the scatter of the next); then compound 3.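

In this assay, the step on the core of compound 2, a number 43.1 percentage points higher from compound 2 to compound 4 (beyond the scatter), shows that the aryl group on the saturated ring carbon strongly shapes the read-out at the concentration tested. Compounds 2 and 4 share that core and differ only in this group, so the near-zero number of compound 2 belongs to the core carrying 4-fluorophenyl and not to the core as such: with 2,5-dimethoxyphenyl in that place, compound 4 gives 43.2%. No measurement here bears on why this exchange has so large an effect.

Going by these compounds, the exchange removes the fluorine and adds two methoxy groups in one step, so it remains open whether the rise follows from losing the fluorine, from one of the methoxy groups, or from both methoxy groups together. Also open, on these data alone, is how far this position tolerates a different kind of substituent on the phenyl ring, such as a dimethylamino group or a carboxylic acid, and whether the step holds when the acetyl group gives way to a longer acyl chain such as butyryl.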